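The source may report more compounds than this note shows. Statements on the series, on what has been measured and on what is new or still open speak of the compounds shown alone.

Compound 1 `COc1cccc(N2C(=O)COc3ccc(-c4cnc(Cl)c(NS(=O)(=O)c5ccc(F)cc5)c4)cc32)c1` carries a 3-methoxyphenyl group on an amide-type nitrogen in a ring. In a functional assay on HepG2 cells (Homo sapiens) for antiproliferative activity, read by MTT assay, with a stated time of 72 h (a lower number here means a stronger inhibitor, a higher number a weaker inhibitor), compound 1 reaches only the limit of the measurement, > 40000 nM. Compound 2 `O=C1COc2ccc(-c3cnc(Cl)c(NS(=O)(=O)c4ccc(F)cc4)c3)cc2N1` arises from compound 1 by the change (hydrogen in place of 3-methoxyphenyl on an amide-type nitrogen in a ring). In this assay compound 2 also stops at a limit, > 40000 nM. The step that the two limits leave unreadable from compound 1 to compound 2 therefore has no readable size, because a limit stands on each side of it (the limit of > 40000 nM in this assay, at which 2 of the 3 values shown sit). Compound 3 `COc1cccc(N2C(=O)COc3ccc(-c4ccc(O)cc4)cc32)c1` keeps the 3-methoxyphenyl group but rests on a different core; the difference between the two cores is not broken down here. In this assay, among the measured compounds shown here, compound 3 gives 26100 nM, the only plain number among the three. Compound 4 `O=C1COc2ccc(-c3ccc(O)cc3)cc2N1` has not yet been measured; it differs from compound 3 by hydrogen in place of 3-methoxyphenyl on an amide-type nitrogen in a ring, the same change as from compound 1 to compound 2, made at the same place. The earlier step gave no readable size, so the expected step of a 1.5-fold higher number from compound 3 to compound 4 (0.19 log units; within the scatter) rests only on the weak value of compound 3, 26100 nM. Compound 4 is expected to give about 40000 nM, with a likely range from 15000 nM to 120000 nM.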

Compound 4, half-maximal inhibitory concentration: 38200 nM
Compound 4: the middle estimate sits 1.0-fold (0.02 log units) above what was measured; low and high end bracket the measured number.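

In this assay, replacing the 3-methoxyphenyl group with hydrogen on the core of compound 3 gives a 1.5-fold higher number from compound 3 to compound 4 (0.17 log units; within the scatter), so on this core the two compounds cannot be told apart. Among the compounds shown here, the same replacement on the core of compound 1 gives no second size to set beside this one, because both compounds in that pair stop at a limit of the assay and their step cannot be read: the limit of > 40000 nM in this assay, at which 2 of the 4 values shown sit. This means that the change has a readable size on only one core, and the data do not show that this size carries over from one core to the other.

The compounds shown leave open what other groups on the amide-type nitrogen would do, such as a short ethyl chain or a phenyl ring carrying an amine or a carboxylic acid. They also leave open whether any such group would give a clearly lower number than hydrogen or 3-methoxyphenyl on either core.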